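The source may report more compounds than this note shows. Statements on the series, on what has been measured and on what is new or still open speak of the compounds shown alone.

Values in a functional assay on MT4 cells (Homo sapiens) for cytotoxicity; on this read-out higher numbers stand for weaker inhibition and lower numbers for stronger inhibition:

compound 1, `N#Cc1c(N)cccc1Sc1cccc(Br)c1`: 53000 nM
compound 2, `N#Cc1cccc(Sc2cccc(N)c2C#N)c1`: 80000 nM
compound 3, `N#Cc1c(N)cccc1[S+]([O-])c1ccccc1Br`: 168000 nM

Within this set, the one measured single-point change is cyano in place of bromo on an aromatic carbon giving a 1.5-fold higher number from compound 1 to compound 2 (0.18 log units; within the scatter). Compound 3 sits at the highest number of the three; against compound 2 and compound 1 its gaps are beyond the scatter. The difference between the core of compound 1 and the core of compound 3 is not broken down here.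

Compound 4, `N#Cc1ccccc1[S+]([O-])c1cccc(N)c1C#N`, is still to be measured in this assay. It differs from compound 3 by cyano in place of bromo on an aromatic carbon. This is the same kind of change as from compound 1 to compound 2, not the same: there the place was meta to a large group, here it is ortho to a large group.

A step of roughly the same modest size is expected, a 1.5-fold higher number from compound 3 to compound 4 (0.17 log units; within the scatter), because a 1.5-fold higher number from compound 1 to compound 2 (0.18 log units; within the scatter) was small and within the scatter. Compound 4 is therefore estimated at 250000 nM, between 120000 nM and 500000 nM.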

Compound 4, half-maximal inhibitory concentration: > 200000 nM
Compound 4: a limit, no number; the forecaster's own chance of this, stated with the estimate: 25%; the middle value is on the limit's open side.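

In this assay compound 4 gives > 200000 nM, which is a limit of the assay and not a number. Cyano in place of bromo therefore yields only a floor on this core, an at least 1.1-fold higher number from compound 3 to compound 4 (0.07 log units; that floor lies within the scatter), and the true size of the step remains unknown. The result does not show that the change carries from one core to the other with the same size, nor does it show that the size differs: the same change on two cores in this assay, a 1.5-fold higher number (0.18 log units; within the scatter) from compound 1 to compound 2 and an at least 1.1-fold higher number (0.07 log units; that floor lies within the scatter) from compound 3 to compound 4; the limit leaves it open whether they differ

The two pairs differ both in their cores and in where the change sits, and the compounds shown do not separate these two factors. Also open, on these data alone, is how an amine or a carboxylic acid would read in place of bromo or cyano on either core.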